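Swapping the aryl amide group from compound 2 to compound 3

The compounds below may be only part of what the source reports. "The series", "measured", "known", "first", "only" and "open" are said of these compounds alone.

Compound 2 (`CN(C)C(=O)c1cc2cnc(Nc3ccc(NC(=O)C4(C(=O)Nc5ccccc5F)CC4)cc3)nc2n1C1CCCC1`) is the lower of the two measured compounds in a functional assay on A549 cells (Homo sapiens) for inhibition, read by CCK-8 assay, with a stated time of 72 h, tested at 10 uM (a lower number here means less inhibition of growth, a higher number more inhibition of growth at the concentration tested), at 88.6%, while compound 1 (`CN(C)C(=O)c1cc2cnc(Nc3ccc(NC(=O)C4(C(=O)Nc5ccc(Cl)cc5)CC4)cc3)nc2n1C1CCCC1`) reaches 101%. Compound 3 (`Cc1ccc(NC(=O)C2(C(=O)Nc3ccc(Nc4ncc5cc(C(=O)N(C)C)n(C6CCCC6)c5n4)cc3)CC2)cc1`) carries 4-methylphenyl in place of 2-fluorophenyl on an amide-type nitrogen. Among the measured compounds shown here, only one measured step bears on this change: a number 12.4 percentage points lower from compound 1 to compound 2 (beyond the scatter), a modest drop beyond the scatter, with 2-fluorophenyl replacing 4-chlorophenyl at the same place. For the measured compounds named here, no measured compound carries 4-methylphenyl, so the expectation rests on that single step and treats 4-methylphenyl as closer to 4-chlorophenyl than to 2-fluorophenyl. A modest upward move, smaller than the measured step and possibly within the scatter, is expected: a number 6.4 percentage points higher from compound 2 to compound 3 (within the scatter). In this assay the estimate for compound 3 is 95%, expected to fall between 84% and 105%.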

Compound 3, percent growth inhibition at one concentration: 90.6%
Compound 3: the middle estimate sits 4.4 percentage points above what was measured; measured number inside the range.
By their numbers in this assay, from the lowest: compounds 2 and 3 (each within the scatter of the next); then compound 1.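

In this assay, 4-methylphenyl in place of 2-fluorophenyl on the amide-type nitrogen gives a number 2 percentage points higher from compound 2 to compound 3 (within the scatter), so this pair does not separate the two groups. Methyl in place of chloro on an aromatic carbon gives a number 10.4 percentage points lower from compound 1 to compound 3 (beyond the scatter); the gap to compound 1 therefore also appears with a group numbered 4 on the ring, and is not tied to 2-fluorophenyl alone. Nothing at hand bears on why the chloro and methyl compounds differ.

Still open, as far as these compounds go, is whether chloro itself matters, or whether 4-bromophenyl or 4-methoxyphenyl would match compound 1 at 101%. The compounds shown also leave untested how a more distinct aryl substituent, such as a carboxylic acid or an amine, would behave at this position.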